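Swapping a Chlorine for a Bromine on the Aryl Ring

A few compounds are considered here, and "the series" means these few. Any claim that something is new, unique, unknown or untested is made for them only; others in the source may bear on it.

The shared core is carried first by compound 1, `Cc1ccc([C@H]2CC(c3ccccc3)=NN2c2ncc(Br)cn2)cc1`, which in a functional assay on the whole organism (strain Wistar albino) for inhibition, with Rattus norvegicus as the target, read by paw edema, with stated times of 30 min and 3 h, at a dose of 20 mg/kg (on this read-out lower numbers stand for less inhibition and higher numbers for more inhibition at the one dose given (going by the name of the read-out)), gives 79%. Its partner compound 2, `Clc1ccc([C@H]2CC(c3ccccc3)=NN2c2ncc(Br)cn2)cc1`, gives 78% in this assay. Among the compounds with values here, the one step measured so far, chloro in place of methyl on an aromatic carbon, is a number 1 percentage points lower from compound 1 to compound 2 (within the scatter), so compound 2 stands alongside compound 1 within the usual scatter of the read-out.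

The next compound, compound 3, is `Brc1ccc([C@H]2CC(c3ccccc3)=NN2c2ncc(Br)cn2)cc1`. It differs from compound 2 by bromo in place of chloro on an aromatic carbon. Within the data shown here, only one measured step speaks to this change: the exchange of methyl for chloro at the same aromatic carbon, which moved the read-out by a number 1 percentage points lower from compound 1 to compound 2 (within the scatter), a shift within the scatter. A second halogen in the same place, bromo for chloro, is therefore expected to leave the read-out in this assay where it is, with any movement staying inside the scatter.

For compound 3 the estimate in this assay is 77%, with a range from 68% to 86%. The expected step, a number 1 percentage points lower from compound 2 to compound 3 (within the scatter), is meant as essentially no change.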

Compound 3, a percentage reported as inhibition, in the whole organism at one dose (the size of the read-out at that dose, not a potency): 76%
The estimate for compound 3 lay 1 percentage points above the measured number, and the stated range covers the measured number.
By their numbers in this assay, from the lowest: compounds 3, 2 and 1 (each within the scatter of the next).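

Compound 3 brings a third group to the same aromatic carbon, para to a large group, and in this assay bromo in place of chloro comes out as a number 2 percentage points lower from compound 2 to compound 3 (within the scatter). Bromo in place of methyl comes out as a number 3 percentage points lower from compound 1 to compound 3 (within the scatter), so all three pairs among methyl, chloro and bromo at this carbon now fall inside the scatter, where before only one pair had been compared. No measurement bears on why these groups cannot be told apart here.

From the compounds shown here alone, whether this carbon stays as undiscriminating with a different kind of group, such as an amine, a carboxylic acid or a longer chain, remains open. Going by these compounds, since the read-out is the size of the effect at a single dose rather than a potency, it also remains open whether compounds that look alike at this dose would still look alike at other doses.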